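The source may hold more compounds than are shown below. What is called first, only, known or untested is meant among the compounds shown, and "the series" means these compounds.

Measured compounds and their values:
- compound 1, `O=C(O)c1ccccc1-c1ccc(CCc2ncc(CCc3ccccc3)[nH]2)cc1`: 174 nM
- compound 2, `O=C(O)c1ccccc1-c1ccc(CCc2ncc(CC3CC3)[nH]2)cc1`: 72 nM

In an in vitro functional assay on cells for agonist activity at Bombesin receptor subtype-3 (Mus musculus), read by luminescence and calcium flux (on this read-out lower numbers stand for an effect already at smaller amounts and higher numbers for an effect only at larger amounts of compound), compound 1 gives 174 nM. In this assay compound 2 gives 72 nM, the lowest of the two numbers in hand; its nearest neighbour is compound 1, and the step of a 2.4-fold lower number from compound 1 to compound 2 (0.38 log units; beyond the scatter) shows how far apart the two lie.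

Compound 3, `N#Cc1ccccc1Cc1cnc(CCc2ccc(-c3ccccc3C(=O)O)cc2)[nH]1`, has not been measured yet. It differs from compound 2 in one place: 2-cyanophenyl in place of cyclopropyl on a saturated chain carbon bound to an aromatic carbon. Going by the values given here, the only measured step that bears on this change is a 2.4-fold lower number from compound 1 to compound 2 (0.38 log units; beyond the scatter), in which a phenyl ring on that chain carbon was replaced by cyclopropyl and the number fell by a modest amount. Among the compounds with values here, compound 3 puts an aromatic ring back on the same carbon, now carrying a nitrile, so the direction of that step is expected to reverse, with the nitrile adding an uncertainty that no measured compound informs. The step from compound 2 to compound 3 is therefore estimated as a 2.1-fold higher number from compound 2 to compound 3 (0.32 log units; beyond the scatter). For compound 3 the expected value is 150 nM, within a range from 40 nM to 600 nM.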

Compound 3, half-maximal effective concentration: 642 nM
Estimate against measurement, compound 3: 4.3-fold (0.63 log units) below; the whole stated range lies below it.
By their numbers in this assay, from the lowest: compound 2; then compound 1; then compound 3.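

In this assay this chain carbon tolerates the groups shown very unequally, and the aromatic ring of compound 3 does more than cancel the earlier gain from cyclopropyl: the change from cyclopropyl to 2-cyanophenyl gives an 8.9-fold higher number from compound 2 to compound 3 (0.95 log units; beyond the scatter), a wider gap than a 2.4-fold lower number from compound 1 to compound 2 (0.38 log units; beyond the scatter). Compound 3 also falls behind the other aromatic compound, with a 3.7-fold higher number from compound 1 to compound 3 (0.57 log units; beyond the scatter), so carrying an aromatic ring at this place does not by itself fix the number, and among these three compounds the small carbon ring of compound 2 gives the lowest value. That last step exchanges benzyl for 2-cyanophenyl as a whole, so the share of the nitrile cannot be separated from the share of the rest of the change.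

Nothing at hand explains why these groups differ in this way. An unsubstituted phenyl or a cyclohexyl on the same chain carbon would be the kind of group needed to tell whether the nitrile, the aromatic ring or simply the size of the group sets the number, and the compounds shown include neither.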